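The source may hold more compounds than are shown below. What is called first, only, known or untested is meant among the compounds shown, and "the series" means these compounds.

Measured compounds:
compound 1, `OC[C@H]1OC(n2cnc3c(-c4ccc(Cl)cc4)ncnc32)[C@H](O)[C@@H]1O` — 900 nM
compound 2, `OC[C@H]1OC(n2cnc3c(-c4ccc(F)c(F)c4)ncnc32)[C@H](O)[C@@H]1O` — 1400 nM
compound 3, `COc1cccc(-c2ncnc3c2ncn3C2O[C@H](CO)[C@@H](O)[C@H]2O)c1` — 4800 nM

In a functional assay on CCRF-CEM cells (Homo sapiens) for inhibition (on this read-out higher numbers stand for weaker inhibition and lower numbers for stronger inhibition), compound 3 gives the highest of the three numbers, separated from compound 2 by a 3.4-fold higher number from compound 2 to compound 3 (0.54 log units; beyond the scatter) and from compound 1 by a 5.3-fold higher number from compound 1 to compound 3 (0.73 log units; beyond the scatter); both gaps lie beyond the scatter. Compounds 1 and 2 differ from each other only by a 1.6-fold higher number from compound 1 to compound 2 (0.19 log units; within the scatter), which is within the scatter.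

Compound 4, `OC[C@H]1OC(n2cnc3c(-c4ccc(F)cc4)ncnc32)[C@H](O)[C@@H]1O`, is not yet measured. It differs from compound 3 by 4-fluorophenyl in place of 3-methoxyphenyl on an aromatic carbon. The two steps that bear on this change are those into compound 3 from the two halogen-bearing phenyl analogues, compound 1 and compound 2, which gave a 5.3-fold higher number from compound 1 to compound 3 (0.73 log units; beyond the scatter) and a 3.4-fold higher number from compound 2 to compound 3 (0.54 log units; beyond the scatter); compound 4 carries a single fluorine on its phenyl ring, as compound 1 carries a single chlorine and compound 2 two fluorines. Reversing the change from a phenyl with one methoxy to a phenyl with one halogen is therefore expected to give a lower number in this assay for compound 4, of a size comparable to those steps, so that compound 4 is expected to fall close to compounds 1 and 2, as a 4.0-fold lower number from compound 3 to compound 4 (0.60 log units; beyond the scatter). The estimate for compound 4 in this assay is 1200 nM, with a range from 550 nM to 2600 nM.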

Compound 4, half-maximal inhibitory concentration: 750 nM
Estimate against measurement, compound 4: 1.6-fold (0.20 log units) above, and the stated range covers the measured number.
By their numbers in this assay, from the lowest: compounds 4, 1 and 2 (each within the scatter of the next); then compound 3.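

At this aromatic carbon, a third halogen-bearing phenyl now separates from 3-methoxyphenyl in this assay, with a 6.4-fold lower number from compound 3 to compound 4 (0.81 log units; beyond the scatter), so compound 3 stands apart from all three halogen-bearing compounds, beyond the scatter in each case. Within that set the changes at the phenyl ring remain unresolved: a 1.2-fold lower number from compound 1 to compound 4 (0.08 log units; within the scatter) and a 1.9-fold lower number from compound 2 to compound 4 (0.27 log units; within the scatter) both lie within the scatter, so neither fluoro in place of chloro nor hydrogen in place of fluoro registers on this read-out. The 3,4-difluorophenyl of compound 2 reads with the 4-substituted phenyls, so a substituent at the 3 position of the phenyl does not by itself go with the higher number.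

Nothing available explains the gap between compound 3 and the halogen-bearing compounds. The compounds shown leave open how an unsubstituted phenyl, a 4-methoxyphenyl or an aminophenyl would read here, and so whether the methoxy group or its place on the ring goes with the higher number.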